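Sec-Butyl for Phenyl: an Expected Gain on a Shared Core

This account rests on a few compounds, and the source may have more. Where it says the series, first, only, none or still open, it means among the compounds named here.

Of the compounds shown here, three built on one core have been measured in an assay on isolated protein for displacement of a labelled ligand from melanin-concentrating hormone receptor 1 (Homo sapiens); a lower number here means a stronger inhibitor, a higher number a weaker inhibitor. Compound 1 `CCCc1cc(N)c2cc(NC(=O)c3ccc(-c4ccc(Cl)cc4)cc3)ccc2n1` gives 0.7 nM, compound 3 `CCCc1cc(N)c2cc(NC(=O)/C=C/c3ccc(CC)cc3)ccc2n1` gives 1.4 nM, and compound 2 `Nc1cc(-c2ccccc2)nc2ccc(NC(=O)/C=C/c3ccc(C(F)(F)F)cc3)cc12` gives 18.5 nM. Compound 2 thus stands at the highest number of the three: its value lies beyond the scatter from that of compound 3, the nearest, and further still from that of compound 1. Compounds 1 and 3 share a propyl at the position where compound 2 carries a phenyl, but each also differs from compound 2 elsewhere, so their lower numbers cannot be tied to the alkyl alone.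

Compound 4 `CCC(C)c1cc(N)c2cc(NC(=O)/C=C/c3ccc(C(F)(F)F)cc3)ccc2n1` keeps the rest of compound 2 and changes only one place (sec-butyl in place of phenyl on an aromatic carbon). Among the compounds with values here, no measured pair shows this exact change. Going by these compounds, since the two compounds carrying an alkyl at this position, compound 1 at 0.7 nM and compound 3 at 1.4 nM, both sit far lower than compound 2, a downward step is expected, of moderate size a 4.6-fold lower number from compound 2 to compound 4 (0.67 log units; beyond the scatter), though the weight of the other differences is unknown. Compound 4 is therefore estimated at 4 nM, within 1 nM to 15 nM.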

Compound 4, half-maximal inhibitory concentration: 0.3 nM
Compound 4: the middle estimate sits 13-fold (1.12 log units) above what was measured; the measured number lies below the stated range.
By their numbers in this assay, from the lowest: compound 4; then compounds 1 and 3 (each within the scatter of the next); then compound 2.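

Within this assay, the change of phenyl to sec-butyl on the aromatic carbon next to the ring nitrogen gives a 62-fold lower number from compound 2 to compound 4 (1.79 log units; beyond the scatter), with the rest of the molecule held constant. The earlier compounds shown here could not show this, as each one carrying an alkyl group at this position also differed from compound 2 elsewhere; this pair ties a large step to this position and this change alone, with a group of 4 heavy atoms and no ring taking the place of a six-membered aromatic ring of 6 heavy atoms. No measurement among those shown explains why the step is so large.

Going by these compounds, whether a propyl, a cyclopropyl or a tert-butyl at this position would match sec-butyl remains open, as this single pair cannot separate what sec-butyl brings from what the loss of phenyl brings. Also open is whether the same change would give a step of similar size alongside the amide side chains of compound 1 and compound 3, as the compounds shown include no phenyl partner for either.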